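The compounds below may be only part of what the source reports. "The series", "measured", "known", "first", "only" and "open" are said of these compounds alone.

Compound 2 `Nc1ccccc1NC(=O)c1ccc(CSC(=S)N2CCN(c3ccncc3)CC2)cc1` gives 77% in a functional assay on HeLa cells (Homo sapiens) for antiproliferative activity, read by CCK-8 assay, with a stated time of 72 h, tested at 2 uM (on this read-out higher numbers stand for a stronger effect at the one concentration tested and lower numbers for a weaker effect), the highest of the three numbers measured here. Compound 1 `Nc1ccccc1NC(=O)c1ccc(CSC(=S)N2CCN(Cc3ccncc3)CC2)cc1` gives 59.5% and compound 3 `Nc1ccccc1NC(=O)c1ccc(CSC(=S)N2CCc3cc(Cl)ccc32)cc1` gives 40.1% in this assay, both beyond the scatter below compound 2. For the measured compounds named here, the only single-place change measured, a number 17.5 percentage points higher from compound 1 to compound 2 (beyond the scatter), lies at the same ring nitrogen that is varied next. Compound 4 `Nc1ccccc1NC(=O)c1ccc(CSC(=S)N2CCN(c3cnccn3)CC2)cc1` differs from compound 2 by pyrazin-2-yl in place of pyridin-4-yl on an amine nitrogen in a ring. Going by the values given here, no measured step swaps one aromatic ring for another at that nitrogen, so the change from compound 2 to compound 4 is expected to stay within the scatter, giving a number 3 percentage points lower from compound 2 to compound 4 (within the scatter). Compound 4 is therefore estimated at 74% in this assay, between 56% and 88%.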

Compound 4, a percentage reported as inhibition, at one concentration (the size of the read-out at that concentration, not a potency): 70.4%
For compound 4 the middle estimate is 3.6 percentage points above the measured one; the measured number falls inside the stated range.
By their numbers in this assay, from the lowest: compound 3; then compound 1; then compounds 4 and 2 (each within the scatter of the next).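

At this ring nitrogen, one aromatic ring can replace another without a clear change: in this assay, pyrazin-2-yl in place of pyridin-4-yl gives a number 6.6 percentage points lower from compound 2 to compound 4 (within the scatter) and stays within the scatter, despite the extra ring nitrogen. Replacing (pyridin-4-yl)methyl also remains beyond the scatter with pyrazin-2-yl as the entering group, with a number 10.9 percentage points higher from compound 1 to compound 4 (beyond the scatter) as the step. No measurement available explains either step. Open, as far as these compounds go, is whether a plain phenyl ring, with no ring nitrogen, would hold the number at this place.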